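The compounds below may be only part of what the source reports. "The series", "measured", "known", "first", "only" and "open" are said of these compounds alone.

Working notes on the series. The shared core of compound 1 `CNC(=O)N1CCCc2ccc(NC(=O)c3cccc(-c4ccccc4)c3)cc21` gives, in a functional assay on MV4-11 cells (Homo sapiens) for antiproliferative activity, with a stated time of 6 days, tested at 1.56 uM (on this read-out higher numbers stand for a stronger effect at the one concentration tested and lower numbers for a weaker effect), compound 1 a value of 2.83%. Compound 2 `CNC(=O)N1CCCc2ccc(NC(=O)c3cccc(-c4ccn(C(C)=O)n4)c3)cc21` gives 27.6% in this assay, and compound 3 `CNC(=O)N1CCCc2ccc(NC(=O)c3ccc(-c4ccccc4)cc3)cc21` gives 19.7%. Compound 3 therefore sits above compound 1 by a gap beyond the scatter, while its gap to compound 2 is within the scatter, so no order between compound 3 and compound 2 can be read from these numbers.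

Compound 4 `CNC(=O)N1CCCc2ccc(NC(=O)c3ccc(-c4cnn(C)c4)cc3)cc21` differs from compound 3 in one place: 1-methyl-1H-pyrazol-4-yl in place of phenyl on an aromatic carbon. Within the data shown here, the only measured step that bears on this is the exchange of phenyl for an acetyl-bearing pyrazolyl group in a number 24.8 percentage points higher from compound 1 to compound 2 (beyond the scatter), which was modest and beyond the scatter. That step is on a different attachment point and with a different pyrazolyl group, so its bearing is loose. A rise of similar or smaller size is nonetheless expected for compound 4, a number 15.3 percentage points higher from compound 3 to compound 4 (beyond the scatter). Compound 4 is estimated at 35% in this assay, within a range of 15% to 58%.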

Compound 4, a percentage reported as inhibition, at one concentration (the size of the read-out at that concentration, not a potency): 77.4%
For compound 4 the middle estimate is 42.4 percentage points below the measured one; the measured number lies above the stated range.
By their numbers in this assay, from the lowest: compound 1; then compounds 3 and 2 (each within the scatter of the next); then compound 4.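

At the aromatic carbon para to a large group, 1-methyl-1H-pyrazol-4-yl in place of phenyl gives a number 57.7 percentage points higher from compound 3 to compound 4 (beyond the scatter) in this assay and so shows that this position can carry a large change in the read-out. The earlier step, a number 24.8 percentage points higher from compound 1 to compound 2 (beyond the scatter), was modest and involved another pyrazolyl group at another attachment point, so it does not show what this exchange shows. The heavy-atom count stays the same here, while a six-membered aromatic ring of carbon only gives way to a five-membered aromatic ring with 2 hetero atoms, and no measurement in hand accounts for the size of the step.

As far as these compounds go, whether an amine or a longer chain in place of the methyl on the pyrazole keeps this level in this assay stays open. Also open, from the compounds shown here alone, is whether 1-methyl-1H-pyrazol-4-yl would give a comparable step at the attachment point of compound 1.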